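This account rests on a few compounds, and the source may have more. Where it says the series, first, only, none or still open, it means among the compounds named here.

In a functional assay for inhibition, with Homo sapiens as the target (on this read-out lower numbers stand for stronger inhibition and higher numbers for weaker inhibition), compound 1 `O=C1CCc2cc(-c3csc(-c4ccccc4)n3)ccc2N1` gives only a limit, > 10000 nM. Among the measured compounds shown here, compound 2 `COc1ccc(-c2nc(-c3ccc4c(c3)CCC(=O)N4)cs2)cc1` gives 9000 nM, the only actual number so far. For the measured compounds named here, the one measured step, an at least 1.1-fold lower number from compound 1 to compound 2 (0.04 log units; that floor lies within the scatter), is bounded by the limit of > 10000 nM in this assay, at which 1 of the 2 values shown sits, and its floor stays within the scatter, so it sets no direction. Compound 3 `O=C1CCc2cc(-c3csc(-c4ccc(O)c(O)c4)n3)ccc2N1` carries 3,4-dihydroxyphenyl in place of 4-methoxyphenyl on an aromatic carbon. Going by the values given here, no measured step covers this exchange, so no shift beyond the scatter is expected in this assay, and the expected change is a 1.8-fold lower number from compound 2 to compound 3 (0.26 log units; within the scatter). The estimate for compound 3 is 5000 nM, with a range of 1000 nM to 20000 nM.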

Compound 3, half-maximal inhibitory concentration: 1000 nM
Compound 3: the middle estimate sits 5.0-fold (0.70 log units) above what was measured, and the stated range covers the measured number.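

Among the compounds shown here, the exchange of 4-methoxyphenyl for 3,4-dihydroxyphenyl on this aromatic carbon gives the first step beyond the scatter (a 9.0-fold lower number from compound 2 to compound 3 (0.95 log units; beyond the scatter)). The same group in place of phenyl also clears the scatter (an at least 10-fold lower number from compound 1 to compound 3 (1.00 log units; beyond the scatter)). Compound 1 gives only a limit, so that second step is a floor: the limit of > 10000 nM in this assay, at which 1 of the 3 values shown sits.

As far as these compounds go, whether one hydroxyl alone would carry the shift stays open, as the step from 4-methoxyphenyl changes both ring substituents at once. Also open, from the compounds shown here alone, is how an amine or a carboxylic acid on that phenyl ring would read in this assay.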